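Heteroaryl swaps on the shared ether-linked imidazoline series

A few compounds are considered here, and "the series" means these few. Any claim that something is new, unique, unknown or untested is made for them only; others in the source may bear on it.

Measured so far:
compound 1 `c1ccc(-c2ccsc2)c(OCC2=NCCN2)c1` — 0.251 nM
compound 2 `Cc1cnsc1-c1ccccc1OCC1=NCCN1` — 12.6 nM

In a functional assay for activation of Alpha-1A adrenergic receptor (Homo sapiens), read by calcium flux (on this read-out higher numbers stand for an effect only at larger amounts of compound and lower numbers for an effect already at smaller amounts), compound 1 gives 0.251 nM, whereas compound 2 gives 12.6 nM. Among the compounds with values here, compound 2 therefore stands at the higher of the two numbers recorded, and its only neighbour is compound 1: the step of a 50-fold higher number from compound 1 to compound 2 (1.70 log units; beyond the scatter) shows how far the two lie apart.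

Compound 3 `Cn1nccc1-c1ccccc1OCC1=NCCN1` has not been measured in this assay. It differs from compound 2 in a single place: 1-methyl-1H-pyrazol-5-yl in place of 4-methyl-1,2-thiazol-5-yl on an aromatic carbon. Within the data shown here, the one measured step that bears on this change is the heteroaryl exchange a 50-fold higher number from compound 1 to compound 2 (1.70 log units; beyond the scatter), a large move on exchanging one five-membered ring with two hetero atoms for another at the same aromatic carbon. That step shows the read-out to be sensitive to the identity of this ring, but it gives no direction for the particular ring entering in compound 3. The expectation for compound 3 is thus a number near that of compound 2, with wide uncertainty in both directions; the expected step is a 1.6-fold higher number from compound 2 to compound 3 (0.20 log units; within the scatter). Compound 3 is estimated at 20 nM, with a range from 3 nM to 150 nM.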

Compound 3, half-maximal effective concentration: 39.8 nM
Estimate against measurement, compound 3: 2.0-fold (0.30 log units) below, and the stated range covers the measured number.
By their numbers in this assay, from the lowest: compound 1; then compound 2; then compound 3.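

In this assay the exchange at this aromatic carbon gives a 3.2-fold higher number from compound 2 to compound 3 (0.50 log units; beyond the scatter) and is a modest move, so the read-out still separates two five-membered aromatic rings that match in heavy atoms, hetero atoms and hydrogen-bond acceptors. Measured against thiophen-3-yl, the same 1-methyl-1H-pyrazol-5-yl ring gives a 160-fold higher number from compound 1 to compound 3 (2.20 log units; beyond the scatter) and this large step exceeds the modest one between the two methyl-bearing rings. Among these three compounds, the choice of thiophen-3-yl over either methyl-bearing ring therefore accounts for far more of the spread than the choice between 4-methyl-1,2-thiazol-5-yl and 1-methyl-1H-pyrazol-5-yl. No measurement at hand explains why these rings read differently.

Within the data shown here, the three compounds do not separate the contribution of the methyl group from that of the ring atoms, as no pair here differs by the methyl group alone. Also open, on these data alone, is how the read-out would respond to a primary amine or a carboxylic acid on the five-membered ring, or to a six-membered pyridine ring at the same aromatic carbon.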